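Pyridin-4-yl in place of pyridin-3-yl in compound 1

This account rests on a few compounds, and the source may have more. Where it says the series, first, only, none or still open, it means among the compounds named here.

For the measured compounds named here, in a functional assay on ileum (Cavia porcellus) for inhibition (a lower number here means a stronger inhibitor, a higher number a weaker inhibitor), compound 1 `COC(=O)C1=C(C)NC(C)=C(C(=O)OC)C1c1c(-c2cccnc2)nc2sc(C)cn12` gives 16000 nM and holds the higher of the two numbers so far. Compound 2 `COC(=O)C1=C(C)NC(C)=C(C(=O)OC)C1c1c(-c2cccs2)nc2sccn12` gives 110 nM and lies beyond the scatter from compound 1. Compound 3 `COC(=O)C1=C(C)NC(C)=C(C(=O)OC)C1c1c(-c2ccncc2)nc2sc(C)cn12` has pyridin-4-yl in place of pyridin-3-yl on an aromatic carbon and otherwise matches compound 1. Going by the values given here, no measured pair shows this change, so only a modest fall in the number in this assay is expected, on thin support. The estimated step is a 2.7-fold lower number from compound 1 to compound 3 (0.43 log units; beyond the scatter) as a rough expectation. For compound 3 the expected value is 6000 nM within an estimated range of 1000 nM to 30000 nM on present data.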

Compound 3, half-maximal inhibitory concentration: 9690 nM
The estimate for compound 3 lay 1.6-fold (0.21 log units) below the measured number, and the stated range covers the measured number.
By their numbers in this assay, from the lowest: compound 2; then compounds 3 and 1 (each within the scatter of the next).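

In this assay, pyridin-4-yl in place of pyridin-3-yl gives a 1.7-fold lower number from compound 1 to compound 3 (0.22 log units; within the scatter) and so stays within the scatter. On this aromatic carbon, this swap of one pyridine isomer for the other therefore makes no readable difference to inhibition. Nothing available bears on why the two isomers read alike.

On these data alone, whether pyridin-2-yl or plain phenyl on this carbon would shift the number remains open. Compound 2 differs from compound 1 in more than one place, so no single change accounts for the gap between them.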